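This account rests on a few compounds, and the source may have more. Where it says the series, first, only, none or still open, it means among the compounds named here.

Working notes on the series. In an assay on isolated protein for inhibition of Nitric oxide synthase, inducible (Homo sapiens), read by scintillation counting, with a stated time of 30 min, tested at 50 uM (on this read-out higher numbers stand for more inhibition at the one concentration tested (going by the name of the read-out) and lower numbers for less inhibition), compound 2 `CC(=O)N1N=C(c2cc(Cl)ccc2N)SC1(C)C` gives 72.8%, compound 3 `CC1(C)SC(c2cc(Cl)ccc2N)=NN1C(=O)C1CC1` gives 23.2%, and compound 1 `COc1ccc(N)c(C2=NN(C(=O)c3ccccc3)C(C)(C)S2)c1` gives 0%. Compound 3 thus stands second highest of the three numbers, above compound 1 and well below compound 2. For the measured compounds named here, the one single-place step measured so far, a number 49.6 percentage points lower from compound 2 to compound 3 (beyond the scatter), is large and downward. Compound 4 `CC1(C)SC(c2cc(Cl)ccc2N)=NN1C(=O)c1ccccc1` differs from compound 3 by phenyl in place of cyclopropyl on a carbonyl carbon. That step bears on it only indirectly: the cyclopropyl already lowered the number sharply, and compound 1, which also carries a phenyl on the carbonyl carbon, shows no inhibition at all. A further fall is therefore expected, a number 15.2 percentage points lower from compound 3 to compound 4 (beyond the scatter), though the scatter limits how far below compound 3 it can be read. Compound 4 is estimated at 8%, within 0% to 30%.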

Compound 4, a percentage reported as inhibition, at one concentration (the size of the read-out at that concentration, not a potency): 20.8%
The estimate for compound 4 lay 12.8 percentage points below the measured number, within the range that was stated.
By their numbers in this assay, from the lowest: compound 1; then compounds 4 and 3 (each within the scatter of the next); then compound 2.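

On the carbonyl carbon, phenyl and cyclopropyl cannot be told apart here, with a number 2.4 percentage points lower from compound 3 to compound 4 (within the scatter) for that exchange. The ring need not be small for the low number to appear, since a number 52 percentage points lower from compound 2 to compound 4 (beyond the scatter) when phenyl replaces methyl, a drop about as large as the one seen with cyclopropyl. The aromatic substituent also matters with phenyl on the carbonyl carbon, as a number 20.8 percentage points higher from compound 1 to compound 4 (beyond the scatter) with chloro in place of methoxy.

Going by these compounds, what an ethyl, a longer chain or an amine on that carbonyl carbon would give remains open. Nothing available explains these steps.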